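Moving from 3-Chlorobenzyl to 2-Methylbenzyl in One Series

The source may report more compounds than this note shows. Statements on the series, on what has been measured and on what is new or still open speak of the compounds shown alone.

Compound 1 `CCCn1c(=O)c2nc(-c3cnn(Cc4cc(C(F)(F)F)ccc4Cl)c3)[nH]c2n(CCC)c1=O`: 1200 nM
Compound 2 `CCCn1c(=O)c2nc(-c3cnn(Cc4cccc(C)c4)c3)[nH]c2n(CCC)c1=O`: 48 nM
Compound 3 `CCCn1c(=O)c2nc(-c3cnn(Cc4cccc(Cl)c4)c3)[nH]c2n(CCC)c1=O`: 31 nM

In an assay on CHO cells for displacement of a labelled ligand from adenosine receptor A1 (Homo sapiens) (on this read-out lower numbers stand for stronger inhibition and higher numbers for weaker inhibition), compound 3 gives the lowest number of the three. Compound 2 sits within the scatter of it (a 1.5-fold lower number from compound 2 to compound 3 (0.19 log units; within the scatter)), while compound 1 lies far behind (a 39-fold lower number from compound 1 to compound 3 (1.59 log units; beyond the scatter)). Compound 4 `CCCn1c(=O)c2nc(-c3cnn(Cc4ccccc4C)c3)[nH]c2n(CCC)c1=O` is not yet measured. The change from compound 3 to compound 4 is 2-methylphenyl in place of 3-chlorophenyl on a saturated chain carbon bound to an aromatic nitrogen. Going by the values given here, two steps bear on it: a 25-fold lower number from compound 1 to compound 2 (1.40 log units; beyond the scatter) and a 39-fold lower number from compound 1 to compound 3 (1.59 log units; beyond the scatter), both large, and both move from a ring carrying a group at its 2-position to one without. Compound 4 brings back a 2-substituent, so a weakening is expected, of moderate size: a 4.8-fold higher number from compound 3 to compound 4 (0.68 log units; beyond the scatter). Compound 4 is thus estimated at 150 nM, within 40 nM to 600 nM.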

Compound 4, inhibition constant: 22 nM
For compound 4 the middle estimate is 6.8-fold (0.83 log units) above the measured one, outside the stated range (below it).
By their numbers in this assay, from the lowest: compounds 4, 3 and 2 (each within the scatter of the next, the first and the last beyond it); then compound 1.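

In this assay, the 2-methylphenyl group of compound 4 cannot be told apart from the 3-chlorophenyl group (a 1.4-fold lower number from compound 3 to compound 4 (0.15 log units; within the scatter)). Placing the methyl as in 2-methylphenyl rather than 3-methylphenyl gives a modest step (a 2.2-fold lower number from compound 2 to compound 4 (0.34 log units; beyond the scatter)), so the placement of this methyl group can be seen in the numbers. The large step from the 2-chloro-5-(trifluoromethyl)phenyl group (a 55-fold lower number from compound 1 to compound 4 (1.74 log units; beyond the scatter)) shows that the high number of compound 1 does not come with every 2-substituted ring.

Going by these compounds, how a 2-chlorobenzyl or a 3-(trifluoromethyl)benzyl group alone would read stays open. No evidence at hand explains these numbers.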